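Chain Length and Growth Inhibition in Hydroxamic Acid Analogues

The source may report more compounds than this note shows. Statements on the series, on what has been measured and on what is new or still open speak of the compounds shown alone.

Compound 1 `Nc1nc2cc(-c3nn(CCCCCCCCCC(=O)NO)c4ncnc(N)c34)ccc2o1`: in a functional assay on HCT-116 cells (Homo sapiens) for inhibition, read by MTT assay, with a stated time of 72 h (on this read-out lower numbers stand for stronger inhibition and higher numbers for weaker inhibition), compound 1 gives 23100 nM.
Compound 2 `Nc1ncnc2c1c(-c1cnc3[nH]ccc3c1)nn2CCC(=O)NO`: in this assay compound 2 gives > 150000 nM, which is a limit of the assay and not a number.
Compound 3 `Nc1nc2cc(-c3nn(CCCCCCCCC(=O)NO)c4ncnc(N)c34)ccc2o1`: in this assay compound 3 gives 2980 nM.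

Compounds 3 and 1 share one core and differ by (hydroxycarbamoyl)methyl in place of hydroxycarbamoyl on a saturated chain carbon, eight bonds along the chain from an aromatic nitrogen. This step gives a 7.8-fold higher number from compound 3 to compound 1 (0.89 log units; beyond the scatter). Compound 2 stands on a different core; the difference between the two cores is not broken down here. For compound 2 only a limit is known, (the limit of > 150000 nM in this assay, at which 1 of the 3 values shown sits).

Compound 4 `Nc1ncnc2c1c(-c1cnc3[nH]ccc3c1)nn2CCCC(=O)NO` has not yet been measured in this assay. It differs from compound 2 by (hydroxycarbamoyl)methyl in place of hydroxycarbamoyl on a saturated chain carbon, two bonds along the chain from an aromatic nitrogen. Within the data shown here, this is the same kind of change as the one from compound 3 to compound 1, but the place is not the same: in the measured pair the group sits on a saturated chain carbon, eight bonds along the chain from an aromatic nitrogen, while in compound 4 it sits on a saturated chain carbon, two bonds along the chain from an aromatic nitrogen.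

Among the measured compounds shown here, compound 4 is expected to show a step that the limit leaves unreadable from compound 2 to compound 4 beside a 7.8-fold higher number from compound 3 to compound 1 (0.89 log units; beyond the scatter), since the one measured step of this kind gave a higher number and compound 2 already sits at a limit. Compound 4 is therefore estimated at 200000 nM, between 60000 nM and 600000 nM, and most likely reported only as a limit.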

Compound 4, half-maximal inhibitory concentration: > 150000 nM
Compound 4: only a limit was reported; the forecaster's own chance of this, stated with the estimate: 75%; the middle value does not contradict the limit.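

In this assay compound 4 gives > 150000 nM, which is a limit of the assay and not a number. Compound 2 stands at that same limit, so no step can be read between compound 2 and compound 4: the limit of > 150000 nM in this assay, at which 2 of the 4 values shown sit.

The compounds shown leave open whether lengthening the chain on the core of compound 2 changes growth inhibition in the way seen on the core of compound 3.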